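This account rests on a few compounds, and the source may have more. Where it says the series, first, only, none or still open, it means among the compounds named here.

- Compound 1 `CCCCCCCCCCCCCCNC(=O)[C@H](CO)/N=C/c1cccc(C)c1`: 51100 nM
- Compound 2 `CCCCCCCCCCCCCCNC(=O)[C@H](CO)/N=C/c1ccccc1C`: 81100 nM

Both values come from an ADME assay on HEK293 cells (Homo sapiens) for cytotoxicity (on this read-out higher numbers stand for weaker inhibition and lower numbers for stronger inhibition), and compound 2, at 81100 nM, lies within the scatter of compound 1. Compound 3 `CCCCCCCCCCCCCCNC(=O)[C@H](CO)/N=C/c1cccc(O)c1` has 3-hydroxyphenyl in place of 2-methylphenyl on a carbon with a double bond to nitrogen. Among the measured compounds shown here, the only measured step, a 1.6-fold higher number from compound 1 to compound 2 (0.20 log units; within the scatter), exchanged 3-methylphenyl for 2-methylphenyl. For the measured compounds named here, no measured compound carries a hydroxyl group, so this step is only a weak guide, and no shift beyond the scatter is expected. The expected step is a 1.4-fold lower number from compound 2 to compound 3 (0.13 log units; within the scatter). Compound 3 is estimated at 60000 nM, with an expected range of 22000 nM to 140000 nM.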

Compound 3, half-maximal inhibitory concentration: 77500 nM
The estimate for compound 3 lay 1.3-fold (0.11 log units) below the measured number; measured number inside the range.
By their numbers in this assay, from the lowest: compounds 1, 3 and 2 (each within the scatter of the next).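

Swapping the 2-methylphenyl for 3-hydroxyphenyl in this assay gives a 1.0-fold lower number from compound 2 to compound 3 (0.02 log units; within the scatter), and replacing methyl with hydroxy on an aromatic carbon gives a 1.5-fold higher number from compound 1 to compound 3 (0.18 log units; within the scatter). A hydroxyl group, with the hydrogen-bond donor and acceptor it adds, therefore leaves all three numbers within the scatter of one another at this place. No measurement here offers an explanation for this result. Still open, as far as these compounds go, is whether a larger difference in the group, such as an amine or a carboxylic acid in place of the hydroxyl, would take the number beyond the scatter.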